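The source may report more compounds than this note shows. Statements on the series, on what has been measured and on what is new or still open speak of the compounds shown alone.

In an ADME assay on HaCaT cells (Homo sapiens) for cytotoxicity, read by MTT assay, with a stated time of 48 h (a higher number here means a weaker inhibitor, a lower number a stronger inhibitor), compound 2 `COc1ccc(-c2nn(-c3ccccc3)cc2-c2nc3cc(Cl)ccc3[nH]2)cc1` gives > 50000 nM, a limit of the assay and not a number. Compound 3 `COc1ccc(-c2nn(-c3ccccc3)cc2-c2nc3cc(OC)ccc3[nH]2)cc1` differs from it by methoxy in place of chloro on an aromatic carbon, with methoxy in place of chloro on an aromatic carbon. Compound 1 `COc1ccc2[nH]c(-c3cn(-c4ccccc4)nc3-c3ccccc3)nc2c1` also carries methoxy on such a carbon and gives > 50000 nM, again a limit. For the measured compounds named here, the series offers no measured step to calibrate against. The expected change in this assay, a step that the limit leaves unreadable from compound 2 to compound 3, is none beyond the scatter, in neither direction. Compound 3 is estimated at 60000 nM, with an expected range of 30000 nM to 120000 nM, and will most likely be reported only as a limit.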

Compound 3, half-maximal inhibitory concentration: > 50000 nM
Compound 3: no number, only a limit (the forecaster's own chance of this, stated with the estimate: 85%); the middle value is on the limit's open side.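

No step can be read among compound 1, compound 2 and compound 3 in this assay, because all three sit at a limit of the assay: the limit of > 50000 nM in this assay, at which 3 of the 3 values shown sit.

As far as these compounds go, whether methoxy in place of chloro or hydrogen on an aromatic carbon changes the read-out in this assay stays open.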